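Phenyl for methoxy on two related cores

This account rests on a few compounds, and the source may have more. Where it says the series, first, only, none or still open, it means among the compounds named here.

Compound 1 `COc1ccc(CN2C(=O)C(=O)c3cc(OC(F)(F)F)ccc32)cc1` gives 1100 nM in a functional assay on CHO cells for agonist activity at muscarinic acetylcholine receptor M5 (Homo sapiens), read by calcium flux; on this read-out lower numbers stand for an effect already at smaller amounts and higher numbers for an effect only at larger amounts of compound. Compound 2 `O=C1C(=O)N(Cc2ccc(-c3ccccc3)cc2)c2ccc(OC(F)(F)F)cc21` gives 2700 nM in this assay. The change between them is phenyl in place of methoxy on an aromatic carbon, and the measured step is a 2.5-fold higher number from compound 1 to compound 2 (0.39 log units; beyond the scatter). Compound 3 `COc1ccc(CN2C(=O)C(=O)c3ccc(OC(F)(F)F)cc32)cc1` has the same atoms as compound 1 joined differently; the difference between the two cores is not broken down here. In this assay compound 3 gives 5700 nM, the highest of the three numbers. Compound 4 `O=C1C(=O)N(Cc2ccc(-c3ccccc3)cc2)c2cc(OC(F)(F)F)ccc21` has not been measured. It differs from compound 3 by phenyl in place of methoxy on an aromatic carbon, the same change as that from compound 1 to compound 2, here on the other core; the change occurs twice among the compounds shown. Among the compounds with values here, for compound 4 the step of a 2.5-fold higher number from compound 3 to compound 4 (0.39 log units; beyond the scatter) is expected in this assay, placed beside the earlier step because a 2.5-fold higher number from compound 1 to compound 2 (0.39 log units; beyond the scatter) is the only measured instance of this change, and the expectation rests on that single pair. Compound 4 is therefore estimated at 14000 nM, with 5000 nM to 40000 nM as the range, and with some chance that the assay reports only a limit.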

Compound 4, half-maximal effective concentration: 2700 nM
For compound 4 the middle estimate is 5.2-fold (0.71 log units) above the measured one; the whole stated range lies above it.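

Phenyl in place of methoxy does not carry over as a fixed step between these two cores in this assay: the step of a 2.1-fold lower number from compound 3 to compound 4 (0.32 log units; beyond the scatter) runs opposite to the one seen on the core of compound 1. The earlier step therefore gives no usable guide to the direction of this change on the core of compound 3, and any transfer of the change within this series has to be tested core by core. The result does not show why the two cores differ, and with a single pair on each core it does not show how general either direction is; the comparison itself reads: the same change on two cores in this assay, a 2.5-fold higher number (0.39 log units; beyond the scatter) from compound 1 to compound 2 and a 2.1-fold lower number (0.32 log units; beyond the scatter) from compound 3 to compound 4, 5.2-fold (0.71 log units) apart, beyond the scatter of two such steps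

The compounds shown cover only methoxy and phenyl at this place, on two cores. On these data alone, whether an amine, a carboxylic acid or a longer chain there would follow either direction stays open, as does the behaviour of the same change on any third core.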